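This account rests on a few compounds, and the source may have more. Where it says the series, first, only, none or still open, it means among the compounds named here.

Compound 1 `COc1ccccc1C(=O)NC(=S)NNc1ncnc2ccccc12` and compound 2 `COc1cc2ncnc(NNC(=S)NC(=O)c3ccc(C(F)(F)F)cc3)c2cc1OC` were both tested in a functional assay on KB cells (Homo sapiens) for cytotoxicity, read by MTT assay, with a stated time of 72 h; a lower number here means a stronger inhibitor, a higher number a weaker inhibitor. Compound 1 reaches only the limit of > 50000 nM, which is a boundary of the measurement rather than a number, so where compound 1 truly stands is not known beyond that point (the limit of > 50000 nM in this assay, at which 1 of the 2 values shown sits). Compound 2, which carries a different core and a trifluoromethyl group on its outer ring, gives a measured 8840 nM, and since compound 1 and compound 2 differ in more than one place, the gap between them cannot be tied to any single change.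

Compound 3 `Cc1ccc(C(=O)NC(=S)NNc2ncnc3ccccc23)cc1` has not yet been measured. It keeps the core of compound 1 and differs from it only in the group attached to the carbonyl carbon (4-methylphenyl in place of 2-methoxyphenyl on a carbonyl carbon). With nothing measured that isolates this change, the step from compound 1 is expected to be small: the estimate for an at least 1.1-fold lower number from compound 1 to compound 3 (0.04 log units; that floor lies within the scatter) is a modest gain at best, and quite possibly none beyond the scatter. On that basis compound 3 is estimated at 45000 nM, within a range of 10000 nM to 150000 nM, with a real chance that only a limit is reported.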

Compound 3, half-maximal inhibitory concentration: 10100 nM
Beside the measured number, compound 3's estimate is 4.5-fold (0.65 log units) above it; the measured number falls inside the stated range.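

Changing only the group on a carbonyl carbon, with the core of compound 1 left as it is, is enough to shift the result in this assay: 4-methylphenyl in place of 2-methoxyphenyl gives an at least 4.9-fold lower number from compound 1 to compound 3 (0.69 log units; beyond the scatter). Among the compounds shown here, this is the first step here that isolates a single change, and it lies beyond the scatter, so this position clearly matters for cytotoxicity in these cells, something the earlier pair, which differs in more than one place, could not show. Compound 1 marks one end of this step with a limit and not a number, so the step gives a floor and not a full size: the limit of > 50000 nM in this assay, at which 1 of the 3 values shown sits.

The compounds shown leave open whether the lower number comes from losing the methoxy group, from gaining the methyl group, or from the different numbering of the group on the phenyl ring, and a 4-methoxyphenyl or a 2-methylphenyl group at this carbonyl carbon would begin to separate these. They also leave open how this position responds to quite different groups, such as an amine or a carboxylic acid on the phenyl ring, or a longer carbon chain in place of the ring.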